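Iodine Replaces Chlorine: Estimating Compound 4

The compounds below may be only part of what the source reports. "The series", "measured", "known", "first", "only" and "open" are said of these compounds alone.

Measured so far:
Compound 1, `Nc1scc(-c2cccc(C(F)(F)F)c2)c1C(=O)c1ccccc1`, gives 83% in a functional assay on CHO cells for agonist activity at adenosine receptor A1 (Homo sapiens), read by fluorescence and ERK phosphorylation, with stated times of 30 min and 1.5 h, tested at 3 uM; a higher number here means a stronger effect of the compound at the concentration tested, a lower number a weaker effect.
Compound 2, `Nc1scc(-c2ccccc2F)c1C(=O)c1ccccc1`, gives 55% in this assay.
Compound 3, `Nc1scc(-c2cccc(Cl)c2)c1C(=O)c1ccccc1`, gives 45% in this assay.

Compound 3 carries the smallest of the three numbers, but its distance to compound 2 is small: the step of a number 10 percentage points lower from compound 2 to compound 3 (within the scatter) lies within the usual scatter, so the two cannot be told apart. Its distance to compound 1 is real: the step of a number 38 percentage points lower from compound 1 to compound 3 (beyond the scatter) is well beyond the scatter.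

Compound 4, `Nc1scc(-c2ccc(I)cc2)c1C(=O)c1ccccc1`, has not yet been measured. It differs from compound 3 in one place: 4-iodophenyl in place of 3-chlorophenyl on an aromatic carbon.

Among the compounds with values here, two measured steps touch the same aromatic carbon of the shared core. The step from compound 1 to compound 3 exchanged one substituent for another and was large. The step from compound 2 to compound 3 changed both the substituent and its position on the phenyl ring and stayed within the scatter. Neither step involves iodine or a 4-substituted phenyl, so there is no direct guide for direction. The expectation is therefore a step of uncertain sign, a number 5 percentage points higher from compound 3 to compound 4 (within the scatter), and compound 4 is expected to give about 50%, within a wide range from 20% to 82%.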

Compound 4, a percentage reported as activity, at one concentration (the size of the read-out at that concentration, not a potency): 51%
The estimate for compound 4 lay 1 percentage points below the measured number; the range from low to high includes it.
By their numbers in this assay, from the lowest: compounds 3, 4 and 2 (each within the scatter of the next); then compound 1.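

In this assay, the switch to 4-iodophenyl gives a number 6 percentage points higher from compound 3 to compound 4 (within the scatter), and replacing 2-fluorophenyl with the same group gives a number 4 percentage points lower from compound 2 to compound 4 (within the scatter). Compound 4 therefore cannot be told apart from compound 2 or compound 3, even though its phenyl group carries a different halogen, in a different place on the ring, from either of theirs. At this aromatic carbon of the shared core, the large step seen so far remains a number 38 percentage points lower from compound 1 to compound 3 (beyond the scatter), and the new result adds no step of that size, while nothing shown explains why these phenyl groups read alike or why compound 1 stands apart.

The compounds shown leave open what the halogen and its place on the ring each contribute, as the step to compound 4 changes both at once; 3-iodophenyl and 4-chlorophenyl would separate the two. Also open, going by these compounds, is how this carbon would respond to a phenyl group carrying an amine or a carboxylic acid, or to 4-trifluoromethylphenyl, which would show whether the group in compound 1 keeps its higher number in another place on the ring.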